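Methoxy for Methyl on the Amide-Type Nitrogen Substituent

The source may report more compounds than this note shows. Statements on the series, on what has been measured and on what is new or still open speak of the compounds shown alone.

Compound 2 `Cc1ccc(NC(=O)/C=C/C(=O)N2C/C(=C\c3ccccc3)C(=O)/C(=C/c3ccccc3)C2)cc1` is one of three compounds tested in a functional assay on L1210 cells (Mus musculus) for cytotoxicity (on this read-out lower numbers stand for stronger inhibition and higher numbers for weaker inhibition), where compound 2 gives 5800 nM. Compound 1 `O=C(/C=C/C(=O)N1C/C(=C\c2ccccc2)C(=O)/C(=C/c2ccccc2)C1)Nc1ccc(Cl)c(Cl)c1` gives 7500 nM, and compound 3 `COc1ccc(NC(=O)/C=C/C(=O)N2C/C(=C\c3ccc([N+](=O)[O-])cc3)C(=O)/C(=C/c3ccc([N+](=O)[O-])cc3)C2)cc1` gives 2900 nM; both of these values lie within the scatter of compound 2, so no ranking of the three can be drawn. Compound 4 `COc1ccc(NC(=O)/C=C/C(=O)N2C/C(=C\c3ccccc3)C(=O)/C(=C/c3ccccc3)C2)cc1` differs from compound 2 in one place: methoxy in place of methyl on an aromatic carbon. Going by the values given here, the only measured step that alters the group on the amide-type nitrogen, a 1.3-fold lower number from compound 1 to compound 2 (0.11 log units; within the scatter), barely moved the read-out. A step of similarly small size is therefore expected here, a 1.2-fold lower number from compound 2 to compound 4 (0.06 log units; within the scatter), with no direction claimed. Compound 4 is estimated at 5000 nM, with a likely range from 2500 nM to 10000 nM.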

Compound 4, half-maximal inhibitory concentration: 6800 nM
Estimate against measurement, compound 4: 1.4-fold (0.13 log units) below, and the stated range covers the measured number.
By their numbers in this assay, from the lowest: compounds 3, 2, 4 and 1 (each within the scatter of the next, the first and the last beyond it).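

In this assay methoxy in place of methyl, para to a large group, gives a 1.2-fold higher number from compound 2 to compound 4 (0.07 log units; within the scatter) and 4-methoxyphenyl in place of 3,4-dichlorophenyl gives a 1.1-fold lower number from compound 1 to compound 4 (0.04 log units; within the scatter) on the same core. Adding an oxygen and a hydrogen-bond acceptor at this position therefore leaves the read-out within the scatter, and all three groups on the amide-type nitrogen of this core lie within the scatter of one another. As far as these compounds go, whether an amine, a carboxylic acid or a longer chain such as butoxy at this position would give a step beyond the scatter stays open. No measurement shown offers an explanation for these small steps.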